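The source may report more compounds than this note shows. Statements on the series, on what has been measured and on what is new or still open speak of the compounds shown alone.

The three measured compounds, with their numbers in an assay for inhibition of transmembrane protease serine 4 (Homo sapiens), read by fluorescence; a higher number here means a weaker inhibitor, a lower number a stronger inhibitor:

Compound 1 `O=C(Nc1cc(C(F)(F)F)cc(C(F)(F)F)c1)c1cccc(Cl)c1O`: 12000 nM
Compound 2 `O=C(Nc1cc(C(F)(F)F)ccc1C(F)(F)F)c1cc(Cl)ccc1O`: 20000 nM
Compound 3 `O=C(Nc1ccc(C(F)(F)F)c(C(F)(F)F)c1)c1cc(Cl)ccc1O`: 13000 nM

All three numbers lie close together: the number of compound 2 sits within the usual scatter of both compound 1 and compound 3, so nothing separates them in this assay. Compound 4 `O=C(Nc1cc(C(F)(F)F)ccc1F)c1cc(Cl)ccc1O` has not yet been measured. It differs from compound 2 by one change: fluoro in place of trifluoromethyl on an aromatic carbon. Among the compounds with values here, no measured pair shows this change, so its effect is unknown here. Given how alike the three measured numbers are, compound 4 is expected to stay in the same weak region, with a step from compound 2 to compound 4 of a 1.1-fold higher number from compound 2 to compound 4 (0.04 log units; within the scatter), at most a small one and not clearly beyond the scatter. The estimate for compound 4 in this assay is 22000 nM, ranging from 8000 nM to 60000 nM.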

Compound 4, half-maximal inhibitory concentration: 28000 nM
The estimate for compound 4 lay 1.3-fold (0.10 log units) below the measured number, and the stated range covers the measured number.
By their numbers in this assay, from the lowest: compounds 1, 3, 2 and 4 (each within the scatter of the next, the first and the last beyond it).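

Within the data shown here, replacing trifluoromethyl with fluoro on this aromatic carbon, para to a trifluoromethyl group, gives a 1.4-fold higher number from compound 2 to compound 4 (0.15 log units; within the scatter) in this assay, the first reading of any change at this position. A trifluoromethyl group here can therefore give way to a single fluorine with no change that stands clear of the scatter, and the inhibitor stays in the same weak region. No supporting measurement bears on why this exchange has so little effect. From the compounds shown here alone, whether an amine, a methoxy group or a carboxylic acid on this carbon would move the number beyond the scatter remains open. Also open, going by these compounds, is whether any group here could give a clearly stronger inhibitor.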